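Notes on the step from compound 3 to compound 4

The compounds below may be only part of what the source reports. "The series", "measured", "known", "first", "only" and "open" are said of these compounds alone.

In a functional assay on A549 cells (Homo sapiens) for antiproliferative activity, read by MTT assay, with a stated time of 72 h (on this read-out lower numbers stand for stronger inhibition and higher numbers for weaker inhibition), compound 1 `CCCNc1ccnc(Nc2ccc(NC(=O)Nc3ccc(Cl)c(C(F)(F)F)c3)cc2)n1` gives 7320 nM, compound 2 `O=C(Nc1ccc(Nc2nccc(Nc3ccccc3Cl)n2)cc1)Nc1ccc(Cl)c(C(F)(F)F)c1` gives 18600 nM and compound 3 `O=C(Nc1ccc(Nc2nccc(Nc3ccc(Cl)cc3)n2)cc1)Nc1ccc(Cl)c(C(F)(F)F)c1` gives 6320 nM. Compound 3 stands level with compound 1 at the low end of these numbers, the gap being a 1.2-fold lower number from compound 1 to compound 3 (0.06 log units; within the scatter). Compound 2 lies clear of both, with a 2.5-fold higher number from compound 1 to compound 2 (0.41 log units; beyond the scatter) and a 2.9-fold lower number from compound 2 to compound 3 (0.47 log units; beyond the scatter).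

The unmeasured compound 4 `Cn1cc(Nc2ccnc(Nc3ccc(NC(=O)Nc4ccc(Cl)c(C(F)(F)F)c4)cc3)n2)cn1` differs from compound 3 at one place: 1-methyl-1H-pyrazol-4-yl in place of 4-chlorophenyl on a nitrogen on an aromatic ring. In words, 1-methyl-1H-pyrazol-4-yl stands in place of 4-chlorophenyl on a nitrogen on an aromatic ring.

Among the compounds with values here, no measured step covers this exact replacement, so the evidence is indirect. All three measured steps change the group on this same nitrogen. The largest of them, the modest 2.9-fold lower number from compound 2 to compound 3 (0.47 log units; beyond the scatter), involves 2-chlorophenyl, a group that compound 4 does not carry. The exchange of propyl for 4-chlorophenyl, a 1.2-fold lower number from compound 1 to compound 3 (0.06 log units; within the scatter), moved nothing beyond the scatter.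

A step beyond the scatter in this assay is therefore not expected, although a slight lean towards a higher number is allowed for. The expected step is a 1.4-fold higher number from compound 3 to compound 4 (0.15 log units; within the scatter). For compound 4 the estimate is 9000 nM, with an expected range of 3500 nM to 23000 nM.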

Compound 4, half-maximal inhibitory concentration: 8610 nM
For compound 4 the middle estimate is 1.0-fold (0.02 log units) above the measured one; measured number inside the range.
By their numbers in this assay, from the lowest: compounds 3, 1 and 4 (each within the scatter of the next); then compound 2.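

In this assay, the 1-methyl-1H-pyrazol-4-yl group, a five-membered aromatic ring with 2 hetero atoms and 2 hydrogen-bond acceptors, replaces the all-carbon ring of 4-chlorophenyl, which has no acceptors, with a 1.4-fold higher number from compound 3 to compound 4 (0.13 log units; within the scatter), and it also replaces propyl with a 1.2-fold higher number from compound 1 to compound 4 (0.07 log units; within the scatter). Within the data shown here, the nitrogen on the aromatic ring therefore now carries three unlike groups (propyl, 4-chlorophenyl and 1-methyl-1H-pyrazol-4-yl) whose numbers all lie within the scatter of one another, and compound 2 is the one compound that goes against this, as a 2.2-fold lower number from compound 2 to compound 4 (0.33 log units; beyond the scatter) shows that its 2-chlorophenyl group also stands apart from a heteroaromatic ring. No measurement at hand speaks to what lies behind these numbers.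

Still open, on these data alone, is whether this tolerance extends to other kinds of group on the same nitrogen, such as an unsubstituted phenyl, a longer chain such as hexyl, an amine such as morpholine or a carboxylic acid. It is also open whether any such group would give a step beyond the scatter towards a lower number, since no group among these does so relative to propyl.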